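Swapping the basic amine chain for a carboxylic acid

The source may report more compounds than this note shows. Statements on the series, on what has been measured and on what is new or still open speak of the compounds shown alone.

Measured so far in a functional assay on MC-38 cells (Mus musculus) for antiproliferative activity, read by CCK-8 assay, with a stated time of 48 h; a higher number here means a weaker inhibitor, a lower number a stronger inhibitor:
- compound 1, `COc1ccc(/C=C\c2cc(OC)c(OC)c(OC)c2)cc1OCc1ccc(CN2CCCCC2C(=O)NCCN)cc1`: > 10000 nM
- compound 2, `COc1ccc(/C=C\c2cc(OC)c(OC)c(OC)c2)cc1OCc1ccc(CNCCNC(C)=O)cc1`: 1800 nM
- compound 3, `COc1ccc(/C=C\c2cc(OC)c(OC)c(OC)c2)cc1OCc1ccc(CNCCN(C)C)cc1`: 1400 nM

The value for compound 1 is a limit of this assay, not a number, and compound 1 is the only one at that limit (the limit of > 10000 nM in this assay, at which 1 of the 3 values shown sits). Compound 3 has the lowest of the two real numbers, and compound 2 sits within the scatter of it, so the two cannot be ranked against each other. Going from the larger group in compound 1 to the smaller chain in compound 2 or in compound 3 gave an at least 5.5-fold lower number from compound 1 to compound 2 (0.74 log units; beyond the scatter) and an at least 7.1-fold lower number from compound 1 to compound 3 (0.85 log units; beyond the scatter), while the exchange between the two small chains gave only a 1.3-fold lower number from compound 2 to compound 3 (0.11 log units; within the scatter).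

Compound 4, `COc1ccc(/C=C\c2cc(OC)c(OC)c(OC)c2)cc1OCc1ccc(CNC(C)(C)C(=O)O)cc1`, is not yet measured. It differs from compound 3 by 1-carboxy-1-methylethyl in place of 2-(dimethylamino)ethyl on an amine nitrogen. Among the compounds with values here, the steps so far show that the two small chains behave alike, whereas the larger group in compound 1 lost activity. The entering group is small, so compound 4 is expected to stay in the range of compound 2 and compound 3, with some risk of a weaker result, an expected step of a 2.1-fold higher number from compound 3 to compound 4 (0.33 log units; beyond the scatter). The estimate for compound 4 in this assay is 3000 nM, expected between 1000 nM and 10000 nM.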

Compound 4, half-maximal inhibitory concentration: > 10000 nM
Compound 4 ended at the assay's limit; the forecaster's own chance of this, stated with the estimate: 25%; middle value at least 3.3-fold (0.52 log units) away from the limit.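

On the amine nitrogen, size alone does not decide the outcome: 1-carboxy-1-methylethyl has 6 heavy atoms in place of the 5 of 2-(dimethylamino)ethyl, yet in this assay this exchange gave an at least 7.1-fold higher number from compound 3 to compound 4 (0.85 log units; beyond the scatter) and ended the measurable activity seen with that chain. Putting the same group in place of 2-acetamidoethyl gave an at least 5.5-fold higher number from compound 2 to compound 4 (0.74 log units; beyond the scatter), so among the small chains shown, the two carrying nitrogen give real numbers and the one carrying a carboxylic acid does not. Compound 1 and compound 4 both stand at a limit and not at a number, so the step between them cannot be read: the limit of > 10000 nM in this assay, at which 2 of the 4 values shown sit.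

The compounds shown leave open whether the carboxylic acid or its two methyl groups matter more. A carboxymethyl chain, without those methyl groups, or the methyl ester of the acid would separate the two.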